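The source may hold more compounds than are shown below. What is called first, only, known or untested is meant among the compounds shown, and "the series" means these compounds.

Measured so far:
- compound 1 `C=C1CC[C@@H]2[C@](C)(CNCc3ccc(C)cc3)[C@H](O)CC[C@@]2(C)[C@@H]1/C=C/C1=CCOC1=O`, which gives 740 nM in a functional assay on BMMC cells (Mus musculus, strain C57BL/6) for inhibition, with stated times of 5 days and 48 h; a higher number here means a weaker inhibitor, a lower number a stronger inhibitor
- compound 2 `C=C1CC[C@@H]2[C@](C)(CNCc3ccc(Br)cc3)[C@H](O)CC[C@@]2(C)[C@@H]1/C=C/C1=CCOC1=O`, which gives 430 nM in this assay

Compound 2 and compound 1 sit within the scatter of each other, as the step of a 1.7-fold lower number from compound 1 to compound 2 (0.24 log units; within the scatter) shows. Compound 3 `C=C1CC[C@@H]2[C@](C)(CNCc3ccc(C#N)cc3)[C@H](O)CC[C@@]2(C)[C@@H]1/C=C/C1=CCOC1=O` differs from compound 2 in one place: cyano in place of bromo on an aromatic carbon. For the measured compounds named here, no measured step exchanges bromo for cyano; the only step on this aromatic carbon, a 1.7-fold lower number from compound 1 to compound 2 (0.24 log units; within the scatter), stays within the scatter, so no shift beyond the scatter is expected in this assay. Compound 3 is therefore estimated at 450 nM, with a range from 150 nM to 1400 nM, an expected step of a 1.0-fold higher number from compound 2 to compound 3 (0.02 log units; within the scatter).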

Compound 3, half-maximal inhibitory concentration: 1130 nM
Beside the measured number, compound 3's estimate is 2.5-fold (0.40 log units) below it; measured number inside the range.
By their numbers in this assay, from the lowest: compounds 2, 1 and 3 (each within the scatter of the next, the first and the last beyond it).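

In this assay this aromatic carbon now shows a change beyond the scatter, though a modest one: cyano in place of bromo gives a 2.6-fold higher number from compound 2 to compound 3 (0.42 log units; beyond the scatter) on the shared core. Cyano in place of methyl gives only a 1.5-fold higher number from compound 1 to compound 3 (0.18 log units; within the scatter), so bromo and cyano separate, while methyl cannot be told apart from either. Nothing available explains the gap between bromo and cyano. Still open, from the compounds shown here alone, is how an amine, a methoxy group or a carboxylic acid on this aromatic carbon would read in this assay.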